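The source may hold more compounds than are shown below. What is called first, only, known or untested is meant among the compounds shown, and "the series" means these compounds.

Measured compounds in a functional assay on MSTO-211H cells (Homo sapiens) for inhibition, read by trypan blue exclusion, with a stated time of 72 h; a lower number here means a stronger inhibitor of growth, a higher number a weaker inhibitor of growth:

Compound 1, `Cc1c(-c2ccc(O)c(O)c2)n(CCCCOc2ccccc2)c2ccc(O)cc12`, gives 3400 nM.
Compound 2, `Cc1c(-c2ccc(O)cc2)n(CCCCOc2ccccc2)c2ccc(O)cc12`, gives 2900 nM.
Compound 3, `Cc1c(-c2ccc(O)cc2)[nH]c2ccccc12`, gives only a limit of the assay, > 20000 nM.

Compound 2 and compound 1 share a core and differ in one place: hydroxy in place of hydrogen on an aromatic carbon. That change produced a 1.2-fold higher number from compound 2 to compound 1 (0.07 log units; within the scatter), so the two values show no difference that the assay can resolve. Compound 3 is built on a different core than compound 2; how the two cores differ is not broken down here. Compound 3 is one of the values that sit at the limit of > 20000 nM in this assay, at which 1 of the 3 values shown sits, so its value is a limit rather than a number.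

Compound 4, `Cc1c(-c2ccc(O)cc2)[nH]c2ccc(O)cc12`, has not yet been measured. It differs from compound 3 in one place: hydroxy in place of hydrogen on an aromatic carbon. For the measured compounds named here, this is the same kind of change as the one from compound 2 to compound 1, but not the same: in compound 1 the entering hydroxy sits ortho to a hydroxy group and meta to a large group on a ring of carbon only, whereas in compound 4 it sits on a ring of carbon only that is part of a fused or bridged system of two rings, meta to a fused ring and para to a fused ring.

Going by the values given here, for compound 4 in this assay the step expected from compound 3 is a step that the limit leaves unreadable from compound 3 to compound 4, a small one, because the only measured hydroxy-for-hydrogen step, a 1.2-fold higher number from compound 2 to compound 1 (0.07 log units; within the scatter), stayed within the scatter. Compound 4 is therefore estimated at 25000 nM, with a range of 8000 nM to 80000 nM, and a good chance that the assay again reports only a limit.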

Compound 4, concentration for 50% growth inhibition: > 20000 nM
Compound 4 ended at the assay's limit; the forecaster's own chance of this, stated with the estimate: 55%; the middle value lies beyond the limit too.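

No step can be read from compound 3 to compound 4 in this assay, since each of the two compounds gives a limit of the assay rather than a number: the limit of > 20000 nM in this assay, at which 2 of the 4 values shown sit. The compounds shown leave open whether hydroxy in place of hydrogen on this aromatic carbon changes growth inhibition at all on the core shared by compound 3 and compound 4.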